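Chain length and ring substituent in an antiproliferative series

The source may report more compounds than this note shows. Statements on the series, on what has been measured and on what is new or still open speak of the compounds shown alone.

Measured compounds:
compound 1 `COc1ccc(-c2cnc3scc(C(=O)NNC(C)=O)n23)cc1` gives 11800 nM
compound 2 `CCC(=O)NNC(=O)c1csc2ncc(-c3ccc(OC)cc3)n12` gives 45800 nM
compound 3 `CCC(=O)NNC(=O)c1csc2ncc(-c3ccc(Br)cc3)n12` gives 19200 nM

These three compounds were tested in a functional assay on HepG2 cells (Homo sapiens) for antiproliferative activity, read by MTT assay, with a stated time of 72 h; a higher number here means a weaker inhibitor, a lower number a stronger inhibitor. Compound 1 and compound 2 share a core and differ by methyl in place of hydrogen on a saturated chain carbon bound to a carbonyl carbon, a change that gave a 3.9-fold higher number from compound 1 to compound 2 (0.59 log units; beyond the scatter). Compound 2 and compound 3 differ in the group on the aromatic ring, bromo in place of methoxy, and that change gave a 2.4-fold lower number from compound 2 to compound 3 (0.38 log units; beyond the scatter). The difference between the cores of compound 1 and compound 3 is not broken down here.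

Compound 4 `CCCC(=O)NNC(=O)c1csc2ncc(-c3ccc(Br)cc3)n12` has not yet been measured in this assay. It differs from compound 3 by methyl in place of hydrogen on a saturated chain carbon, two bonds along the chain from a carbonyl carbon. Going by the values given here, this is the same kind of change as the one from compound 1 to compound 2, but not the same: there the methyl entered on a saturated chain carbon bound to a carbonyl carbon, here it enters two bonds along the chain from a carbonyl carbon. Since the earlier lengthening gave a 3.9-fold higher number from compound 1 to compound 2 (0.59 log units; beyond the scatter), a further lengthening is expected to weaken again, though by less, so the step from compound 3 to compound 4 is estimated as a 1.8-fold higher number from compound 3 to compound 4 (0.26 log units; within the scatter). Compound 4 is therefore expected to give about 35000 nM, between 12000 nM and 100000 nM.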

Compound 4, half-maximal inhibitory concentration: 33600 nM
Compound 4: the middle estimate sits 1.0-fold (0.02 log units) above what was measured, within the range that was stated.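

In this assay the added methyl on the chain of the bromo compounds gave a 1.8-fold higher number from compound 3 to compound 4 (0.24 log units; within the scatter) and so, taken alone, this step cannot be told apart from the spread of repeat measurements. Set beside the earlier step on the methoxy compounds, it points the same way, and the two steps do not differ by more than that spread allows: the same change on two cores in this assay, a 3.9-fold higher number (0.59 log units; beyond the scatter) from compound 1 to compound 2 and a 1.8-fold higher number (0.24 log units; within the scatter) from compound 3 to compound 4, 2.2-fold (0.35 log units) apart, within the scatter of two such steps. Going by these compounds alone, this fits the idea that lengthening the chain carries over from one core to the other, but it does not show an equal effect on both: only one of the two steps stands clear of the scatter, and the methyl enters at a different place on the chain in each.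

The compounds shown leave open whether a longer chain, such as a pentanoyl group, or a branched one would follow the same direction. They also leave open how the chain behaves with other groups on the aromatic ring, such as chloro or trifluoromethyl.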